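This account rests on a few compounds, and the source may have more. Where it says the series, first, only, none or still open, it means among the compounds named here.

Compound 1, `Cc1cc(NC(=O)CN2CCC(c3cccc[n+]3[O-])CC2)ccc1F`, gives 18 nM in a functional assay on HEK293 cells for agonist activity at D(4) dopamine receptor (Homo sapiens), read by FLIPR; on this read-out higher numbers stand for an effect only at larger amounts of compound and lower numbers for an effect already at smaller amounts. Compound 2, `O=C(CN1CCC(c2cccc[n+]2[O-])CC1)Nc1ccc(F)cc1`, gives 85 nM in this assay and so holds the highest of the two numbers measured; its nearest neighbour is compound 1, and the step of a 4.7-fold higher number from compound 1 to compound 2 (0.67 log units; beyond the scatter) separates them. Compound 3, `CSc1cccc(NC(=O)CN2CCC(c3cccc[n+]3[O-])CC2)c1`, has not yet been measured in this assay. It differs from compound 2 by 3-(methylsulfanyl)phenyl in place of 4-fluorophenyl on an amide-type nitrogen. Going by the values given here, only one measured step bears on this change, a 4.7-fold higher number from compound 1 to compound 2 (0.67 log units; beyond the scatter), and it concerns a different kind of alteration on the same aromatic ring, a hydrogen in place of a methyl; it shows that a substituent on that ring can shift the number by a modest amount, but it says nothing about a sulfur-bearing group nor about moving a substituent to another position. The expectation for compound 3 is therefore a small shift at most, a 1.4-fold lower number from compound 2 to compound 3 (0.15 log units; within the scatter), with wide uncertainty. Compound 3 is estimated at 60 nM, in a range from 15 nM to 250 nM.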

Compound 3, half-maximal effective concentration: 100 nM
The estimate for compound 3 lay 1.7-fold (0.22 log units) below the measured number, and the stated range covers the measured number.
By their numbers in this assay, from the lowest: compound 1; then compounds 2 and 3 (each within the scatter of the next).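

Putting 3-(methylsulfanyl)phenyl in place of 4-fluorophenyl on the amide-type nitrogen leaves the read-out in this assay within the scatter (a 1.2-fold higher number from compound 2 to compound 3 (0.07 log units; within the scatter)), even though the entering group has a sulfur instead of a fluorine, one heavy atom more and one hydrogen-bond acceptor where the leaving group has none. The earlier compounds had shown only the loss of a methyl on this ring, whereas this result shows that a different substituent, carrying a different name and number on the ring, can give a number that cannot be told apart from that of compound 2. Compound 1 remains separate from this pair, with the replacement of 4-fluoro-3-methylphenyl beyond the scatter (a 5.6-fold higher number from compound 1 to compound 3 (0.74 log units; beyond the scatter)), so among these three compounds only compound 1 stands apart.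

Because the entering and leaving groups differ in both substituent and ring numbering, these compounds cannot separate those two features, and they leave open what a plain phenyl, or an amine or a carboxylic acid on this ring, would give. No experimental evidence is available to explain these numbers.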